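From cyclohexyl to cyclopropyl in compound 3

The source may hold more compounds than are shown below. What is called first, only, known or untested is meant among the compounds shown, and "the series" means these compounds.

In a functional assay on MV4-11 cells (Homo sapiens) for antiproliferative activity, read by luminescence and CellTiter-Glo, with a stated time of 72 h (a lower number here means a stronger inhibitor, a higher number a weaker inhibitor), compound 1 (`CNc1cc(-c2ccc3cnn(Cc4ccc(C)cc4)c3c2)cn(C)c1=O`) gives 3280 nM and compound 2 (`CNc1cc(-c2ccc3cnn(Cc4ccc(F)c(F)c4)c3c2)cn(C)c1=O`) gives 320 nM on the same core. Compound 3 (`CNc1cc(-c2ccc3cnn(CC4CCCCC4)c3c2)cn(C)c1=O`) gives 2690 nM and sits level with compound 1 while lying well above compound 2. Compound 4 (`CNc1cc(-c2ccc3cnn(CC4CC4)c3c2)cn(C)c1=O`) differs from compound 3 by one change (cyclopropyl in place of cyclohexyl on a saturated chain carbon bound to an aromatic nitrogen) that puts cyclopropyl in place of cyclohexyl on a saturated chain carbon bound to an aromatic nitrogen. Three measured steps involve this same place. One is a 10-fold lower number from compound 1 to compound 2 (1.01 log units; beyond the scatter) and shows that a change here can matter. The others are a 1.2-fold lower number from compound 1 to compound 3 (0.09 log units; within the scatter) and an 8.4-fold higher number from compound 2 to compound 3 (0.92 log units; beyond the scatter) and both end on the cyclohexyl group. None of them shrinks a saturated ring, so the guidance is only indirect. In this assay the expected step is a 1.4-fold higher number from compound 3 to compound 4 (0.15 log units; within the scatter) and it may well stay within the scatter, with a higher number the likelier direction. Compound 4 is estimated at 3800 nM with a range of 1400 nM to 10000 nM expected.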

Compound 4, half-maximal inhibitory concentration: 3450 nM
For compound 4 the middle estimate is 1.1-fold (0.04 log units) above the measured one; measured number inside the range.
By their numbers in this assay, from the lowest: compound 2; then compounds 3, 1 and 4 (each within the scatter of the next).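

In this assay, shrinking the saturated ring makes no clear difference: a 1.3-fold higher number from compound 3 to compound 4 (0.11 log units; within the scatter) stays within the usual scatter, even though the group falls from 6 heavy atoms to 3. Compound 4 also cannot be told apart from the 4-methylphenyl group of the first compound, with a 1.1-fold higher number from compound 1 to compound 4 (0.02 log units; within the scatter) also within the scatter, whereas an 11-fold higher number from compound 2 to compound 4 (1.03 log units; beyond the scatter) lies beyond it, so among these four groups on the saturated chain carbon only the 3,4-difluorophenyl group of compound 2 stands apart. No measurement shown here accounts for that difference.

From the compounds shown here alone, it remains open whether a single fluorine, as in a 4-fluorophenyl group, would give a number close to that of compound 2. How an amine or a carboxylic acid would read at this place is also unknown.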